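This account rests on a few compounds, and the source may have more. Where it says the series, first, only, none or still open, it means among the compounds named here.

Measured in a functional assay on MDA-MB-231 cells (Homo sapiens) for inhibition, read by MTT assay, with a stated time of 48 h; on this read-out higher numbers stand for weaker inhibition and lower numbers for stronger inhibition:
- compound 1 `COc1cc(-c2cc(-c3cccc([N+](=O)[O-])c3)nc(-c3ccccc3)n2)cc(OC)c1OC`: 2440 nM
- compound 2 `COc1cc(-c2cc(-c3cccs3)nc(-c3ccccc3)n2)cc(OC)c1OC`: 5110 nM

Compound 2 has the higher of the two numbers, so it is the weaker inhibitor here. Next comes compound 3 `COc1cc(-c2cc(-c3ccc(N)cc3)nc(-c3ccccc3)n2)cc(OC)c1OC`, with this change: 4-aminophenyl in place of thiophen-2-yl on an aromatic carbon. In words, 4-aminophenyl takes the place of thiophen-2-yl on an aromatic carbon.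

Going by the values given here, only one measured step bears on this, and it is modest: a 2.1-fold higher number from compound 1 to compound 2 (0.32 log units; beyond the scatter). That step put thiophen-2-yl in place of 3-nitrophenyl. Among the compounds with values here, compound 3 returns a six-membered aromatic ring to that place, but with a different substituent, and no measured compound carries 4-aminophenyl. A modest move to a lower number is therefore expected, about the size of the measured step and in the opposite direction, though the support is thin. The expected step is a 1.8-fold lower number from compound 2 to compound 3 (0.26 log units; within the scatter). Compound 3 is estimated at 2800 nM, with a range of 1000 nM to 8000 nM.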

Compound 3, half-maximal inhibitory concentration: 1010 nM
The estimate for compound 3 lay 2.8-fold (0.44 log units) above the measured number; measured number inside the range.
By their numbers in this assay, from the lowest: compound 3; then compound 1; then compound 2.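

In this assay, 4-aminophenyl gives the lowest number of the three compounds at this position on the aromatic carbon, with a 5.1-fold lower number from compound 2 to compound 3 (0.70 log units; beyond the scatter) and a 2.4-fold lower number from compound 1 to compound 3 (0.38 log units; beyond the scatter). Both steps lie beyond the scatter, so compound 3 is the strongest inhibitor shown, and the two compounds with a six-membered aromatic ring here also differ from each other, so ring size alone does not set the number. No measurement available here accounts for these steps.

The compounds shown leave open whether the amine itself carries the lower number, since a plain phenyl group at this position would be needed to separate the ring from its substituent. They also leave open whether a hydroxyl or a carboxylic acid in place of the amine would give a similar number.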